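Switching the Aryl Group on the Shared Core

The compounds below may be only part of what the source reports. "The series", "measured", "known", "first", "only" and "open" are said of these compounds alone.

compound 1: `OC[C@H]1O[C@@H](n2cnc3c(NCc4ccccc4Br)ncnc32)[C@H](O)[C@@H]1O` — > 166000 nM
compound 2: `OC[C@H]1O[C@@H](n2cnc3c(NCc4ccc(Cl)cc4Cl)ncnc32)[C@H](O)[C@@H]1O` — 128000 nM
compound 3: `OC[C@H]1O[C@@H](n2cnc3c(NCc4c(F)ccc(F)c4F)ncnc32)[C@H](O)[C@@H]1O` — > 166000 nM

All three were tested in a functional assay on G-361 cells (Homo sapiens) for antiproliferative activity, with a stated time of 72 h; a lower number here means a stronger inhibitor, a higher number a weaker inhibitor. For compound 1 the value > 166000 nM is a limit of the assay, not a number. Compound 3 likewise gives only a limit, > 166000 nM. Compound 2 yields a number, 128000 nM. Because (the limit of > 166000 nM in this assay, at which 2 of the 3 values shown sit), compound 1 cannot be placed more exactly than at the ceiling. Compound 4 `OC[C@H]1O[C@@H](n2cnc3c(NCc4ccc(C(F)(F)F)cc4)ncnc32)[C@H](O)[C@@H]1O` differs from compound 1 in one place: 4-(trifluoromethyl)phenyl in place of 2-bromophenyl on a saturated chain carbon bound to a nitrogen on an aromatic ring. The measured steps at this place are an at least 1.2-fold lower number from compound 1 to compound 2 (0.11 log units; that floor lies within the scatter), a step that the two limits leave unreadable from compound 1 to compound 3 and an at least 1.2-fold higher number from compound 2 to compound 3 (0.11 log units; that floor lies within the scatter); none leaves the scatter. No step beyond the scatter is therefore expected in this assay. Compound 4 is expected at 166000 nM, range 90000 nM to 330000 nM, which is expected to mean a number no higher from compound 1 to compound 4 (the limit leaves the size open), most probably reported again as a limit.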

Compound 4, half-maximal inhibitory concentration: > 166000 nM
Compound 4 gave a limit, no number; the forecaster's own chance of this, stated with the estimate: 70%; the middle value lies on the limit itself.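

In this assay compound 4 also gives only a limit, so a group with trifluoromethyl in place of a ring halogen, 4-(trifluoromethyl)phenyl, still yields no number at this place. The one readable step is an at least 1.2-fold higher number from compound 2 to compound 4 (0.11 log units; that floor lies within the scatter), so this change is not shown to separate the two compounds. The steps from compound 1 and compound 3 to compound 4 cannot be read: the limit of > 166000 nM in this assay, at which 3 of the 4 values shown sit.

From the compounds shown here alone, whether these three limit compounds differ from one another stays open. So does whether an aryl group bearing an amine or a carboxylic acid, or a longer chain at this place, would give a clearly lower number.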